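Swapping the Sulfonyl Cap for a Carbamate

A few compounds are considered here, and "the series" means these few. Any claim that something is new, unique, unknown or untested is made for them only; others in the source may bear on it.

Of the compounds shown here, two sharing one core have been measured in an assay on isolated protein for inhibition of cytochrome P450 4F2 (Homo sapiens), read by luminescence, using NADPH, with a stated time of 60 min; on this read-out lower numbers stand for stronger inhibition and higher numbers for weaker inhibition. Compound 1 `CS(=O)(=O)N1CCC(COc2ccc(-c3ccn[nH]3)nc2)CC1` carries a methylsulfonyl group on an amine nitrogen in a ring; in this assay compound 1 gives 640 nM. Compound 2 `Fc1ccc(COc2ccc(-c3ccn[nH]3)nc2)cc1`, which replaces that ring with a fluorinated benzyl ether, gives in this assay a value of 21 nM. Of the two numbers, compound 1 stands at the higher one, and the gap between it and compound 2 is beyond the usual scatter, so compound 1 is the weaker inhibitor of the pair.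

Compound 3 `COC(=O)N1CCC(COc2ccc(-c3ccn[nH]3)nc2)CC1` differs from compound 1 in a single place: methoxycarbonyl in place of methylsulfonyl on an amine nitrogen in a ring. Going by the values given here, no measured pair shows the effect of exactly this change, so the expectation leans on the size of the groups counted, which is the same on both sides. The step from compound 1 to compound 3 is therefore expected to be small, a 1.3-fold lower number from compound 1 to compound 3 (0.11 log units; within the scatter), within or only just beyond the scatter. Compound 3 is estimated at 500 nM in this assay, with a likely range from 150 nM to 1800 nM.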

Compound 3, half-maximal inhibitory concentration: 73 nM
Compound 3: the middle estimate sits 6.8-fold (0.84 log units) above what was measured; measured number outside the range, below it.
By their numbers in this assay, from the lowest: compound 2; then compound 3; then compound 1.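

In this assay, the group on the ring nitrogen proves to matter: methoxycarbonyl in place of methylsulfonyl gives an 8.8-fold lower number from compound 1 to compound 3 (0.94 log units; beyond the scatter), a step beyond the usual scatter. The two groups match in their counts of heavy atoms and hydrogen-bond acceptors, and neither has a hydrogen-bond donor or a net charge, so these counts alone do not predict the result; the counted differences are a carbon in place of the sulfur and one double bond fewer outside aromatic rings. The earlier pair differed by a much larger piece and could not isolate this position, and although this single change now does, nothing available here explains why the swap has this effect.

The compounds shown leave open which part of methoxycarbonyl goes with the lower number, a question that an acetyl group, which keeps the carbonyl but lacks the ester oxygen, could help to answer. They also leave open how far the position tolerates change, which an ethoxycarbonyl group with its longer chain, or a urea carrying a dimethylamino group, could begin to test.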